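The source may hold more compounds than are shown below. What is called first, only, known or untested is meant among the compounds shown, and "the series" means these compounds.

Compound 1 `CC(C)[C@H](C(=O)Nc1ncc(C(F)(F)F)s1)c1ccc(Cl)cc1` and compound 2 `CC(C)(C)[C@H](C(=O)Nc1ncc(C(F)(F)F)s1)c1ccc(Cl)cc1` share one core and differ in a single spot: methyl in place of hydrogen on a saturated chain carbon bound to three saturated chain carbons In a functional assay on CHO cells for agonist activity at Free fatty acid receptor 2 (Homo sapiens), read by cAMP accumulation (on this read-out higher numbers stand for larger maximal responses and lower numbers for smaller maximal responses), compound 1 gives 95%, and compound 2 gives 95%, so the added methyl made no change at the digits printed from compound 1 to compound 2 (within the scatter).

Compound 3 `CCC[C@H](C(=O)Nc1nccs1)c1ccc(Cl)cc1` is built on another core; the difference between the two cores is not broken down here. In this assay compound 3 gives 108%, the highest of the three values, and its gap to compound 1 and to compound 2 lies beyond the scatter.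

Compound 4 `CC(C)C[C@H](C(=O)Nc1nccs1)c1ccc(Cl)cc1` has not yet been measured. For the measured compounds named here, it differs from compound 3 by methyl in place of hydrogen on a saturated chain carbon bound to two saturated chain carbons This is the same kind of change as the one from compound 1 to compound 2, but not the same: there the carbon was bound to three saturated chain carbons, here it is bound to two.

Since the earlier methyl made no change at the digits printed from compound 1 to compound 2 (within the scatter), the step from compound 3 to compound 4 is expected to be small, about a number 2 percentage points lower from compound 3 to compound 4 (within the scatter). Compound 4 is therefore estimated to give 106% in this assay, expected to fall between 92% and 120%.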

Compound 4, largest response reached (reported as efficacy), in percent of the reference or control that the assay uses: 68%
Compound 4: middle estimate off by 38 percentage points, on the high side; the whole stated range lies above it.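

In this assay, the methyl that turns the propyl chain of compound 3 into the isobutyl chain of compound 4 gave a number 40 percentage points lower from compound 3 to compound 4 (beyond the scatter). This shows that, in this series, a methyl in place of hydrogen on a chain carbon does not bring the same change on every core, so the result on one core could not simply be carried over to the other: the same change on two cores in this assay, no change at the digits printed (within the scatter) from compound 1 to compound 2 and a number 40 percentage points lower (beyond the scatter) from compound 3 to compound 4, 40 percentage points apart, beyond the scatter of two such steps. It does not show why the two steps differ: the methyl sits on a saturated chain carbon bound to three saturated chain carbons in one pair and on one bound to two in the other, and the cores differ as well, so these two pairs cannot separate the place of the methyl from the core.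

The compounds shown leave open how the response would change with a longer chain, such as pentyl, or with an amine or a carboxylic acid on that chain. They also leave open whether the same methyl, placed on a carbon bound to two saturated chain carbons on the core of compound 1, would behave as it did on the core of compound 3.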